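Swapping the aryl group on the ring amide nitrogen

The compounds below may be only part of what the source reports. "The series", "measured", "known", "first", "only" and "open" are said of these compounds alone.

The account concerns two measured compounds and one still to be measured. Compound 1 `O=C(NCCCCc1ccccc1)c1cccc(C2SCC(=O)N2c2cnccn2)c1` was tested in a functional assay on HOS-TE85 cells (Homo sapiens) for inhibition, read by CCK-8 assay, with a stated time of 72 h; on this read-out lower numbers stand for stronger inhibition and higher numbers for weaker inhibition. In this assay compound 1 gives only a limit, > 1000 nM, and no number. What is known of where compound 1 stands therefore rests on the limit of > 1000 nM in this assay, at which 1 of the 2 values shown sits, alone. Compound 2 `O=C(NCCCCn1cccn1)c1cccc(C2SCC(=O)N2c2cc(Cl)ccn2)c1` carries a different chain and a different aryl group on the ring nitrogen; in this assay compound 2 gives 36.4 nM. Among the compounds with values here, no pair of measured compounds differs in a single place, so no measured step sets a scale for the change at hand.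

Compound 3 `CC(F)(F)c1cccc(N2C(=O)CSC2c2cccc(C(=O)NCCCCc3ccccc3)c2)c1` differs from compound 1 by a group of 10 heavy atoms (8 carbon, 2 fluorine; one six-membered aromatic ring of carbon only) in place of a group of 6 heavy atoms (4 carbon, 2 nitrogen; one six-membered aromatic ring with 2 hetero atoms), on an amide-type nitrogen in a ring. Since compound 1 sits at a limit, the step of an at least 2.0-fold lower number from compound 1 to compound 3 (0.30 log units; that floor lies within the scatter) that the estimate implies is expected to be a gain of uncertain size, and it may well stay within the scatter. Compound 3 is expected to give 500 nM in this assay, with a range from 100 nM to 3000 nM, and a fair chance remains that it, too, is reported only as a limit.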

Compound 3, half-maximal inhibitory concentration: 29.1 nM
For compound 3 the middle estimate is 17-fold (1.24 log units) above the measured one, outside the stated range (below it).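

Within the data shown here, with the chain and the rest of the core held fixed, replacing pyrazin-2-yl on the amide-type nitrogen in the ring with the carbon-only aromatic group bearing fluorine gives an at least 34-fold lower number from compound 1 to compound 3 (1.53 log units; beyond the scatter), the first single-place step. It shows that the group at this one position can decide whether a compound gives a measured value in this assay, and that the chain shared by compound 1 and compound 3 does not by itself hold a compound at a limit. The step is only a floor, and its full size cannot be read, because one end of it is a limit rather than a number: the limit of > 1000 nM in this assay, at which 1 of the 3 values shown sits.

The compounds shown leave open which part of the entering group carries the gain, since a plain phenyl ring or a phenyl ring bearing a nitrile at this nitrogen would separate the aromatic ring from its fluorine-bearing substituent. They also leave open whether the same change would have a similar effect alongside another chain, such as a shorter alkyl chain or one ending in an amine.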